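Swapping Isopropyl for Pyridin-4-yl on the Amide

A few compounds are considered here, and "the series" means these few. Any claim that something is new, unique, unknown or untested is made for them only; others in the source may bear on it.

Of the compounds shown here, two have so far been measured in an assay on isolated protein for binding affinity to secreted frizzled-related protein 1 (Homo sapiens), read by fluorescence; on this read-out higher numbers stand for weaker inhibition and lower numbers for stronger inhibition. Compound 1 `O=C(CN1CCNCC1)N1CCC(NS(=O)(=O)c2cc(S(=O)(=O)c3ccccc3)ccc2C(F)(F)F)CC1` gives 140 nM, while compound 2 `CC(C)C(=O)N1CCC[C@H]1C(=O)N1CCC(NS(=O)(=O)c2cc(S(=O)(=O)c3ccccc3)ccc2C(F)(F)F)CC1` gives 40 nM, the lower of the two numbers; the step is a 3.5-fold lower number from compound 1 to compound 2 (0.54 log units; beyond the scatter). Compound 3 `O=C([C@@H]1CCCN1C(=O)c1ccncc1)N1CCC(NS(=O)(=O)c2cc(S(=O)(=O)c3ccccc3)ccc2C(F)(F)F)CC1` differs from compound 2 by pyridin-4-yl in place of isopropyl on a carbonyl carbon. For the measured compounds named here, the single measured step changed a different part of the molecule, so it does not bear directly on this exchange, and no other measurement speaks to it. With nothing pointing either way, the expected step is a 1.1-fold higher number from compound 2 to compound 3 (0.05 log units; within the scatter), within the scatter. Compound 3 is therefore estimated at 45 nM, with a range from 15 nM to 140 nM.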

Compound 3, half-maximal inhibitory concentration: 70 nM
Compound 3: middle estimate off by 1.6-fold (0.19 log units), on the low side, within the range that was stated.
By their numbers in this assay, from the lowest: compounds 2, 3 and 1 (each within the scatter of the next, the first and the last beyond it).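

In this assay, putting pyridin-4-yl in place of isopropyl on the carbonyl carbon gives a 1.8-fold higher number from compound 2 to compound 3 (0.24 log units; within the scatter). This position therefore accepts a larger group with a six-membered aromatic ring, with no change beyond the scatter. Nothing available explains how these two different groups come to read alike.

The compounds shown leave open whether a phenyl group, which has no ring nitrogen, or a longer alkyl chain on this carbonyl carbon would also stay within the scatter of compound 2. They also cannot say whether the ring nitrogen of pyridin-4-yl matters here at all.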